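Chloro for Methoxy on the Benzyl Arm of Compound 1

The source may hold more compounds than are shown below. What is called first, only, known or untested is meant among the compounds shown, and "the series" means these compounds.

Measured compounds:
compound 1, `COc1ccc(CN2C(=O)/C(=C\c3cc(OC)c(OC)c(OC)c3)c3ccccc32)cc1`, 2200 nM
compound 2, `COc1cc(/C=C2\C(=O)N(C)c3ccc(Cl)cc32)cc(OC)c1OC`, 2300 nM

In a functional assay on cells (Leukemia cell, Homo sapiens) for cytotoxicity, with a stated time of 48 h (on this read-out lower numbers stand for stronger inhibition of growth and higher numbers for weaker inhibition of growth), compound 1 gives 2200 nM, the lowest of the two numbers shown, yet compound 2 at 2300 nM sits within the usual scatter of it, so the two cannot be told apart. Among the compounds with values here, no pair of measured compounds differs in a single place, so no measured step is available.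

Compound 3, `COc1cc(/C=C2\C(=O)N(Cc3ccc(Cl)cc3)c3ccccc32)cc(OC)c1OC`, has not yet been tested. It differs from compound 1 by chloro in place of methoxy on an aromatic carbon. Within the data shown here, nothing among the measured compounds shows how this change acts, and the two measured values themselves are indistinguishable. Compound 3 is therefore expected to land close to compound 1, with a step of a 1.1-fold lower number from compound 1 to compound 3 (0.04 log units; within the scatter) that is estimated to be none beyond the scatter, in either direction. The estimate for compound 3 in this assay is 2000 nM, with a range from 900 nM to 4500 nM.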

Compound 3, concentration for 50% growth inhibition: 1500 nM
Compound 3: the middle estimate sits 1.3-fold (0.12 log units) above what was measured, and the stated range covers the measured number.
By their numbers in this assay, from the lowest: compounds 3, 1 and 2 (each within the scatter of the next).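

In this assay, exchanging 4-methoxybenzyl for 4-chlorobenzyl gives a 1.5-fold lower number from compound 1 to compound 3 (0.17 log units; within the scatter), the first single-place step measured in this series. At this aromatic carbon, then, methoxy with its hydrogen-bond acceptor can give way to chloro, which has none, without a change beyond the scatter. No available measurement explains why the step is this small.

On these data alone, whether an amine or a carboxylic acid on the same aromatic carbon would also stay within the scatter remains open. Compound 2 differs from compound 1 and compound 3 in more than one place, so steps to it cannot be read, and whether the same exchange would behave alike elsewhere on the molecule is also unresolved.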